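Swapping furan for thiophene on a thiosemicarbazone

The compounds below may be only part of what the source reports. "The series", "measured", "known", "first", "only" and "open" are said of these compounds alone.

Measured compounds, in a functional assay on PC-3 cells (Homo sapiens) for inhibition, read by sulforhodamine B assay, with a stated time of 48 h; on this read-out lower numbers stand for stronger inhibition of growth and higher numbers for weaker inhibition of growth:
Compound 1 `CC1=CC[C@H](C(C)(C)NC(=S)N/N=C/c2ccccc2Cl)CC1` gives 700 nM
Compound 2 `CC1=CC[C@H](C(C)(C)NC(=S)N/N=C/c2cccc(Cl)c2)CC1` gives 6600 nM
Compound 3 `CC1=CC[C@H](C(C)(C)NC(=S)N/N=C/c2ccco2)CC1` gives 27200 nM

All three share the same core and differ only in the aromatic group attached to the carbon with a double bond to nitrogen. Compound 3 stands at the highest number of the three, meaning the weakest growth inhibition: the nearest neighbour is compound 2, seen in a 4.1-fold higher number from compound 2 to compound 3 (0.62 log units; beyond the scatter), and the furthest is compound 1, seen in a 39-fold higher number from compound 1 to compound 3 (1.59 log units; beyond the scatter). Moving from 2-chlorophenyl to 3-chlorophenyl already weakened inhibition, as a 9.4-fold higher number from compound 1 to compound 2 (0.97 log units; beyond the scatter) shows.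

Compound 4 `CC1=CC[C@H](C(C)(C)NC(=S)N/N=C/c2cccs2)CC1` is not yet measured. Its change from compound 3 is thiophen-2-yl in place of furan-2-yl on a carbon with a double bond to nitrogen. Among the measured compounds shown here, none of the measured steps exchanges one five-membered ring for another; they only show that the aromatic group at this position moves the result over a wide span. Thiophen-2-yl and furan-2-yl are both five-membered aromatic rings with one hetero atom, so a modest shift in either direction is plausible, with no firm basis for a large one. The expected step of a 2.3-fold lower number from compound 3 to compound 4 (0.36 log units; beyond the scatter) is a small move toward stronger inhibition. For compound 4 the estimate in this assay is 12000 nM, within 3000 nM to 50000 nM.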

Compound 4, concentration for total growth inhibition: 62800 nM
For compound 4 the middle estimate is 5.2-fold (0.72 log units) below the measured one; the measured number lies above the stated range.
By their numbers in this assay, from the lowest: compound 1; then compound 2; then compound 3; then compound 4.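

In this assay, exchanging one five-membered aromatic ring for another with the same counts of heavy atoms, donors and acceptors still shifts the result beyond the scatter, and the shift is toward weaker inhibition of growth (a 2.3-fold higher number from compound 3 to compound 4 (0.36 log units; beyond the scatter)). Sulfur in place of oxygen in the ring therefore matters at this position, and the distance from the chlorinated rings grows to (a 9.5-fold higher number from compound 2 to compound 4 (0.98 log units; beyond the scatter)) and (a 90-fold higher number from compound 1 to compound 4 (1.95 log units; beyond the scatter)), which makes compound 4 the weakest of the four and leaves both five-membered rings weaker than both chlorophenyl groups. Nothing available here explains why the thiophen-2-yl group gives a higher number than the furan-2-yl group.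

The compounds shown leave open whether the chlorine or the six-membered ring itself sets the stronger inhibition, a question that plain phenyl would address, and whether a ring nitrogen, as in pyridin-2-yl, would behave like the five-membered rings or like the chlorophenyl groups. They also leave open how a methoxy group or a bromine would compare with chlorine on the six-membered ring.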